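Replacing 2-Chlorophenyl with 2-Phenylethenyl on the Shared Core

The compounds below may be only part of what the source reports. "The series", "measured", "known", "first", "only" and "open" are said of these compounds alone.

Compound 1 `Cc1cc(O)c(C2=NN(c3ccc(S(N)(=O)=O)cc3)C(c3ccccc3O)C2)cc1Cl`: in a functional assay on UACC-62 cells (Homo sapiens) for antiproliferative activity, with a stated time of 48 h (a higher number here means that more compound is tolerated, a lower number that less compound is tolerated), compound 1 gives 40800 nM.
Compound 2 `Cc1cc(O)c(C2=NN(c3ccc(S(N)(=O)=O)cc3)C(c3ccccc3Cl)C2)cc1Cl`: in this assay compound 2 gives 43400 nM.

Of these two numbers, compound 2 holds the higher one, with compound 1 nearest; the step of a 1.1-fold higher number from compound 1 to compound 2 (0.03 log units; within the scatter) lies within the scatter, so the two compounds cannot be ordered. Compound 3 `Cc1cc(O)c(C2=NN(c3ccc(S(N)(=O)=O)cc3)C(/C=C/c3ccccc3)C2)cc1Cl` differs from compound 2 in one place: 2-phenylethenyl in place of 2-chlorophenyl on a saturated ring carbon. For the measured compounds named here, no measured step involves a change of this kind, since the only step available exchanges one substituent on an aromatic carbon and stays within the scatter, whereas here the whole aromatic ring gives way to a chain carrying a double bond. With both measured values lying close together, compound 3 is expected to fall near them, an expected step of a 1.2-fold lower number from compound 2 to compound 3 (0.09 log units; within the scatter). For compound 3 the estimated value in this assay is 35000 nM, with a range from 12000 nM to 100000 nM.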

Compound 3, concentration lethal to 50% of the cells: 34000 nM
Compound 3: middle estimate off by 1.0-fold (0.01 log units), on the high side; the measured number falls inside the stated range.
By their numbers in this assay, from the lowest: compounds 3, 1 and 2 (each within the scatter of the next).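

On the saturated ring carbon of the shared core, in this assay, the step of a 1.3-fold lower number from compound 2 to compound 3 (0.11 log units; within the scatter) shows that a double bond can stand between this carbon and the aromatic ring without the number leaving the scatter. The step of a 1.2-fold lower number from compound 1 to compound 3 (0.08 log units; within the scatter) reads the same way, so 2-chlorophenyl, 2-hydroxyphenyl and 2-phenylethenyl cannot be ordered at this position, although the last differs from the other two in more than a single substituent on the ring. Nothing available here accounts for this result.

From the compounds shown here alone, all three groups carry a six-membered aromatic ring of carbon, so it remains open whether a group without one, such as a plain hexyl chain, an amine or a carboxylic acid, would give a step beyond the scatter. Going by these compounds, it also remains open whether the same holds when the 4-sulfamoylphenyl group is exchanged for another group.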